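Inverting the second ring stereocentre of compound 2

The compounds below may be only part of what the source reports. "The series", "measured", "known", "first", "only" and "open" are said of these compounds alone.

Compound 1 `COC(=O)[C@@H]1CN(C)CC[C@@H]1c1ccc2ccccc2c1` is the stronger of the two measured compounds: in an assay on a subcellular fraction from brain for inhibition of Norepinephrine transporter (Rattus norvegicus) (on this read-out lower numbers stand for stronger inhibition and higher numbers for weaker inhibition), compound 1 gives 34 nM. Its diastereomer compound 2 `COC(=O)[C@H]1CN(C)CC[C@@H]1c1ccc2ccccc2c1` gives 241 nM in this assay, the highest of the two numbers, and the step of a 7.1-fold higher number from compound 1 to compound 2 (0.85 log units; beyond the scatter) lies beyond the scatter; the only thing that could account for it is the fact that compounds 1 and 2 differ only in the configuration as drawn. Compound 3 `COC(=O)[C@H]1CN(C)CC[C@H]1c1ccc2ccccc2c1` is now considered; it differs from compound 2 as follows: the two compounds have the same atoms and bonds and differ only in configuration as drawn: 1 of 2 stereo elements differ; a stereocentre at a saturated ring carbon is drawn S in compound 2 and R in compound 3. Within the data shown here, the one measured step that bears on this change is a 7.1-fold higher number from compound 1 to compound 2 (0.85 log units; beyond the scatter), which shows that inverting one ring stereocentre in this core moved the number by a modest amount beyond the scatter. A step of comparable size is therefore expected from compound 2 to compound 3, in a direction the data do not settle, written as a 1.6-fold lower number from compound 2 to compound 3 (0.21 log units; within the scatter). Compound 3 is estimated at 150 nM in this assay, within 30 nM to 800 nM.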

Compound 3, inhibition constant: 38 nM
Compound 3: middle estimate off by 3.9-fold (0.60 log units), on the high side, and the stated range covers the measured number.
By their numbers in this assay, from the lowest: compounds 1 and 3 (each within the scatter of the next); then compound 2.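

The second ring stereocentre proved able to move the number on its own, in the direction opposite to the earlier inversion: a 6.3-fold lower number from compound 2 to compound 3 (0.80 log units; beyond the scatter) in this assay. Inverting both stereocentres together gives no change beyond the scatter, a 1.1-fold higher number from compound 1 to compound 3 (0.05 log units; within the scatter), so this assay does not distinguish the mirror-image pair of compounds 1 and 3, and compound 2 alone stands apart among the three. Configuration is the only difference that can account for the step from compound 2 to compound 3: the fact that compounds 2 and 3 differ only in the configuration as drawn

The compounds shown leave open where the mirror image of compound 2 would fall in this assay. They also leave open whether the same dependence on configuration would hold with a carboxylic acid or an amide in place of the ester.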